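Chain terminus swap on the shared core

The source may report more compounds than this note shows. Statements on the series, on what has been measured and on what is new or still open speak of the compounds shown alone.

Measured in a functional assay on PANC-1 cells (Homo sapiens) for inhibition, read by MTT assay, with a stated time of 24 h, tested at 10 uM; on this read-out higher numbers stand for more inhibition at the one concentration tested (going by the name of the read-out) and lower numbers for less inhibition:
compound 1, `CC(C)=CCC1Cc2c(OCCCNS(=O)(=O)c3ccc(Cl)cc3)cc(=O)n(CCCO)c2CC1(C)C`: 9.8%
compound 2, `CC(C)=CCC1Cc2c(OCCCNC(=O)c3ccc([N+](=O)[O-])cc3)cc(=O)n(CCCO)c2CC1(C)C`: 9.1%

Compound 2 stands lowest of the two numbers, with compound 1 nearest; the step of a number 0.7 percentage points lower from compound 1 to compound 2 (within the scatter) is within the scatter. Compound 3, `COc1ccc(OCCCOc2cc(=O)n(CCCO)c3c2CC(CC=C(C)C)C(C)(C)C3)cc1`, differs from compound 2 by 4-methoxyphenoxy in place of ((4-nitrophenyl)carbonyl)amino on a saturated chain carbon, three bonds along the chain from an oxygen on an aromatic ring. For the measured compounds named here, the only measured step, a number 0.7 percentage points lower from compound 1 to compound 2 (within the scatter), changed the group on the amine nitrogen and showed nothing beyond scatter, so for this larger change no step beyond the scatter is expected: a number 0.4 percentage points higher from compound 2 to compound 3 (within the scatter). Compound 3 is estimated at 9.5% in this assay, expected between 0% and 25%.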

Compound 3, a percentage reported as inhibition, at one concentration (the size of the read-out at that concentration, not a potency): 4.1%
The estimate for compound 3 lay 5.4 percentage points above the measured number, within the range that was stated.
By their numbers in this assay, from the lowest: compounds 3, 2 and 1 (each within the scatter of the next).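

Swapping ((4-nitrophenyl)carbonyl)amino or ((4-chlorophenyl)sulfonyl)amino for 4-methoxyphenoxy, on a saturated chain carbon, three bonds along the chain from an oxygen on an aromatic ring, gives no step beyond the scatter in this assay, with a number 5 percentage points lower from compound 2 to compound 3 (within the scatter) and a number 5.7 percentage points lower from compound 1 to compound 3 (within the scatter). An amino link at this place is thus not shown to matter at the one concentration tested, since a terminus without nitrogen reads the same within the scatter. No evidence bears on this result.

Open, on these data alone, is whether a basic amine or a carboxylic acid at this chain end, or a longer chain, would move the number beyond the scatter.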